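Series notes: chloro substitution on the phenoxy ring

The source may report more compounds than this note shows. Statements on the series, on what has been measured and on what is new or still open speak of the compounds shown alone.

Compound 3 `N[C@@H](COP(=O)(O)OCCCOC(=O)CCc1ccccc1OCc1cccc(Oc2ccc(Cl)cc2)c1)C(=O)O` gives 17.8% in an assay on cells for agonist activity at probable G-protein coupled receptor 34 (Mus musculus), with a stated time of 1 h; a lower number here means a smaller maximal response, a higher number a larger maximal response. It stands at the low end of the three numbers shown, but the gaps to both other compounds are within the scatter: compound 1 `N[C@@H](COP(=O)(O)OCCCOC(=O)CCc1ccccc1OCc1cccc(Oc2ccccc2)c1)C(=O)O` gives 19.4% and compound 2 `N[C@@H](COP(=O)(O)OCCCOC(=O)CCc1ccccc1OCc1cccc(Oc2ccccc2Cl)c1)C(=O)O` gives 19.8%, and the steps of a number 1.6 percentage points lower from compound 1 to compound 3 (within the scatter) and a number 2 percentage points lower from compound 2 to compound 3 (within the scatter) both fall inside the usual spread of repeated measurements.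

Compound 4 `N[C@@H](COP(=O)(O)OCCCOC(=O)CCc1ccccc1OCc1cccc(Oc2ccc(Cl)c(Cl)c2)c1)C(=O)O` is not yet measured. It differs from compound 3 by chloro in place of hydrogen on an aromatic carbon.

Two measured steps are of the same kind of change: a number 0.4 percentage points higher from compound 1 to compound 2 (within the scatter) and a number 1.6 percentage points lower from compound 1 to compound 3 (within the scatter). Neither moved the maximal response beyond the scatter. The third step, a number 2 percentage points lower from compound 2 to compound 3 (within the scatter), stayed within it as well. Within the data shown here, nothing among the measured compounds shows a chloro group on this ring shifting the maximal response.

No step beyond the scatter is therefore expected, a number 0.2 percentage points higher from compound 3 to compound 4 (within the scatter).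

Compound 4 is expected to give 18%, with a range from 13% to 24%.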

Compound 4, largest response reached (Emax), in percent of the reference or control that the assay uses: 18%
The estimate for compound 4 equals the measured number at the digits printed; low and high end bracket the measured number.
By their numbers in this assay, from the lowest: compounds 3, 4, 1 and 2 (each within the scatter of the next).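

A second chloro group, ortho to a chloro group and meta to a large group, leaves the maximal response in this assay unmoved even when the ring already carries one chloro group: a number 0.2 percentage points higher from compound 3 to compound 4 (within the scatter). The 3,4-dichlorophenyl group also stays within the scatter of the phenyl and 2-chlorophenyl groups, with a number 1.4 percentage points lower from compound 1 to compound 4 (within the scatter) and a number 1.8 percentage points lower from compound 2 to compound 4 (within the scatter). The exchange of hydrogen for chloro now reads alike from two different starting compounds: the same change on two cores in this assay, a number 0.4 percentage points higher (within the scatter) from compound 1 to compound 2 and a number 0.2 percentage points higher (within the scatter) from compound 3 to compound 4, 0.2 percentage points apart, within the scatter of two such steps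

From the compounds shown here alone, only hydrogen and chloro appear on this ring, so whether a methoxy group, an amine or a carboxylic acid there would move the maximal response beyond the scatter stays open. Also open, going by these compounds, is whether a change elsewhere on the shared core, such as a longer chain, would do so.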